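The source may hold more compounds than are shown below. What is called first, only, known or untested is meant among the compounds shown, and "the series" means these compounds.

Measured so far:
compound 1 `COc1ccc(Cn2cc(CNC(=O)c3cn(-c4ccccc4)nc3-c3ccccc3)nn2)cc1` 6900 nM
compound 2 `O=C(NCc1cn(Cc2ccc(Cl)cc2)nn1)c1cn(-c2ccccc2)nc1-c1ccc(F)cc1` 210 nM
compound 3 `O=C(NCc1cn(Cc2ccc(C(F)(F)F)cc2)nn1)c1cn(-c2ccccc2)nc1-c1ccc(F)cc1` 250 nM

In a functional assay on HeLa cells (Homo sapiens) for antiproliferative activity, read by sulforhodamine B assay, with a stated time of 48 h (on this read-out higher numbers stand for weaker inhibition of growth and lower numbers for stronger inhibition of growth), compound 3 stands second highest of the three numbers, close to compound 2 and far from compound 1. Compound 4 `COc1ccc(Cn2cc(CNC(=O)c3cn(-c4ccccc4)nc3-c3ccc(F)cc3)nn2)cc1` differs from compound 3 by methoxy in place of trifluoromethyl on an aromatic carbon. Within the data shown here, no measured step makes this exact change. Among the measured compounds shown here, the only step at this place, a 1.2-fold higher number from compound 2 to compound 3 (0.08 log units; within the scatter), was within the scatter. For the measured compounds named here, compound 1, which carries the same methoxybenzyl but lacks the fluoro on the other ring, gives a much higher number than compounds 2 and 3, and no step separates those two differences. Compound 4 is therefore expected to give a higher number, estimated as 1500 nM with a range of 400 nM to 6000 nM, a step of a 6.0-fold higher number from compound 3 to compound 4 (0.78 log units; beyond the scatter).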

Compound 4, concentration for 50% growth inhibition: 870 nM
For compound 4 the middle estimate is 1.7-fold (0.24 log units) above the measured one, within the range that was stated.
By their numbers in this assay, from the lowest: compounds 2 and 3 (each within the scatter of the next); then compound 4; then compound 1.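

In this assay this position clearly responds to its group: 4-methoxybenzyl gives weaker growth inhibition than 4-(trifluoromethyl)benzyl (a 3.5-fold higher number from compound 3 to compound 4 (0.54 log units; beyond the scatter)) and than the chloro analogue (a 4.1-fold higher number from compound 2 to compound 4 (0.62 log units; beyond the scatter)). The fluoro on the other ring also matters (a 7.9-fold lower number from compound 1 to compound 4 (0.90 log units; beyond the scatter)), so the high number of compound 1 reflects both differences, not methoxy alone. Nothing here explains either effect. From the compounds shown here alone, how an amine or a carboxylic acid would behave at this position remains open, as does whether the fluoro step holds with chloro or trifluoromethyl in place of methoxy.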